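The source may report more compounds than this note shows. Statements on the series, on what has been measured and on what is new or still open speak of the compounds shown alone.

Of the compounds shown here, three sharing one core have been tested in a functional assay on A549 cells (Homo sapiens) for antiproliferative activity, read by MTT assay; on this read-out higher numbers stand for weaker inhibition and lower numbers for stronger inhibition. Compound 1 `Cn1c(=O)c(=O)n(C2CCCC2)c2nc(N/N=C/c3ccc(C(F)(F)F)cc3)ncc21` gives 40600 nM. Compound 2 `Cn1c(=O)c(=O)n(C2CCCC2)c2nc(N/N=C/c3cccs3)ncc21` reaches only the limit of the assay, > 100000 nM. Compound 3 `Cn1c(=O)c(=O)n(C2CCCC2)c2nc(N/N=C/c3ccc(F)cc3Br)ncc21` gives 6590 nM, the lowest of the two numbers; the two steps leading to it, a 6.2-fold lower number from compound 1 to compound 3 (0.79 log units; beyond the scatter) and an at least 15-fold lower number from compound 2 to compound 3 (1.18 log units; beyond the scatter), both came from changing the group on the carbon with a double bond to nitrogen, while an at least 2.4-fold higher number from compound 1 to compound 2 (0.39 log units; beyond the scatter) went the other way. Compound 4 `Cn1c(=O)c(=O)n(C2CCCC2)c2nc(N/N=C/c3cccc([N+](=O)[O-])c3)ncc21` differs from compound 3 by 3-nitrophenyl in place of 2-bromo-4-fluorophenyl on a carbon with a double bond to nitrogen. Swapping that aryl group gave modest to large steps before, so compound 4 is expected to be weaker than compound 3, by roughly a 3.0-fold higher number from compound 3 to compound 4 (0.48 log units; beyond the scatter). Compound 4 is therefore estimated at 20000 nM, likely between 5000 nM and 80000 nM.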

Compound 4, half-maximal inhibitory concentration: 12300 nM
Estimate against measurement, compound 4: 1.6-fold (0.21 log units) above; the measured number falls inside the stated range.
By their numbers in this assay, from the lowest: compounds 3 and 4 (each within the scatter of the next); then compound 1. At a limit, above all of these: compound 2.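

Two quite different rings on this carbon, 3-nitrophenyl and 2-bromo-4-fluorophenyl, cannot be told apart, with a 1.9-fold higher number from compound 3 to compound 4 (0.27 log units; within the scatter). The 3-nitrophenyl group also gives lower numbers than two other groups at this place, with a 3.3-fold lower number from compound 1 to compound 4 (0.52 log units; beyond the scatter) and an at least 8.1-fold lower number from compound 2 to compound 4 (0.91 log units; beyond the scatter). The second of these steps is only a bound, since the value for compound 2 is a limit and not a number: the limit of > 100000 nM in this assay, at which 1 of the 4 values shown sits.

Still open, going by these compounds, is how much the nitro group itself contributes. A plain phenyl ring, or an amine in place of the nitro group, would help to answer that.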